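The source may hold more compounds than are shown below. What is called first, only, known or untested is meant among the compounds shown, and "the series" means these compounds.

Going by the values given here, compound 2 `COc1cc2nc(N3CCC(OCC(C)(C)O)CC3)nc(N)c2cc1OC` gives 1.28 nM in an assay on brain for displacement of a labelled ligand from Adrenergic receptor alpha-1 (Rattus norvegicus) (on this read-out lower numbers stand for stronger inhibition and higher numbers for weaker inhibition), the higher of the two numbers measured so far, though only by a margin within the scatter. Its nearest neighbour, compound 1 `CCOC(C)COC1CCN(c2nc(N)c3cc(OC)c(OC)cc3n2)CC1`, gives 0.99 nM in this assay. Compound 3 `CCOC(COC1CCN(c2nc(N)c3cc(OC)c(OC)cc3n2)CC1)c1ccccc1` differs from compound 2 by ethoxy(phenyl)methyl in place of 1-hydroxy-1-methylethyl on a saturated chain carbon bound to an oxygen on a saturated carbon. A single measured step bears on this place: a 1.3-fold higher number from compound 1 to compound 2 (0.11 log units; within the scatter), which exchanged one chain for another on the same saturated carbon without carrying the number beyond the scatter. Among the compounds with values here, the new change is considerably larger than that earlier one, since the entering group brings an aromatic ring where none stood before, so the one comparison available guides only loosely; what it does show is that this position has so far tolerated alteration. Compound 3 is therefore expected to show a 1.3-fold higher number from compound 2 to compound 3 (0.10 log units; within the scatter), with a value estimated at 1.6 nM, in a range from 0.5 nM to 5 nM.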

Compound 3, inhibition constant: 0.52 nM
The estimate for compound 3 lay 3.1-fold (0.49 log units) above the measured number; low and high end bracket the measured number.
By their numbers in this assay, from the lowest: compounds 3, 1 and 2 (each within the scatter of the next, the first and the last beyond it).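

Going by these compounds alone, the step of a 2.5-fold lower number from compound 2 to compound 3 (0.39 log units; beyond the scatter) is the first change at this place to pass beyond the scatter in this assay, and it shows that ethoxy(phenyl)methyl, with its six-membered aromatic ring, is accepted here in place of 1-hydroxy-1-methylethyl with no rise in the number. Phenyl in place of methyl, with the ethoxy kept, gives a 1.9-fold lower number from compound 1 to compound 3 (0.28 log units; within the scatter), so this exchange of the ring for methyl stays within the scatter on its own. No available evidence accounts for either step.

From the compounds shown here alone, how far the ethoxy and the phenyl each contribute to the step away from 1-hydroxy-1-methylethyl remains open. So does the response of this place to a pyridine ring, an amine or a carboxylic acid.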